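Piperazine nitrogen substituent change in a benzamide series

The source may report more compounds than this note shows. Statements on the series, on what has been measured and on what is new or still open speak of the compounds shown alone.

Measured compounds:
compound 1 `CN1CCN(C2(CNC(=O)c3ccccc3OCc3ccccc3)Cc3ccccc3C2)CC1` — an assay on HEK293 cells for inhibition of potassium/sodium hyperpolarization-activated cyclic nucleotide-gated channel 1 (Homo sapiens), with a stated time of 30 min; a lower number here means a stronger inhibitor, a higher number a weaker inhibitor: 631 nM
compound 2 `CCOc1ccccc1C(=O)NCC1(N2CCN(CC)CC2)CCCCC1` — this assay: 31.6 nM

Within the data shown here, compound 2 stands at the lowest of the two numbers; compound 1 gives a number far above it, beyond the scatter, but the two differ in several places at once, so the pair offers no single step. Compound 3 `CCOc1ccccc1C(=O)NCC1(N2CCN(C3CCC3)CC2)CCCCC1` differs from compound 2 by cyclobutyl in place of ethyl on an amine nitrogen in a ring. Among the measured compounds shown here, no comparable step has been measured in this assay, so a small step in either direction, possibly none beyond the scatter, is expected, described by a 1.0-fold higher number from compound 2 to compound 3 (0.01 log units; within the scatter). For compound 3 the estimate is 32 nM, within 10 nM to 100 nM.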

Compound 3, half-maximal inhibitory concentration: 79.4 nM
Compound 3: middle estimate off by 2.5-fold (0.39 log units), on the low side; measured number inside the range.
By their numbers in this assay, from the lowest: compound 2; then compound 3; then compound 1.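

Among these compounds, on the amine nitrogen in the six-membered ring, cyclobutyl in place of ethyl gives a 2.5-fold higher number from compound 2 to compound 3 (0.40 log units; beyond the scatter) in this assay and is the first single-place step. The change is beyond the scatter but modest, so this position accepts a four-membered carbon ring with only a limited loss of inhibition. Nothing measured here explains the step.

As far as these compounds go, whether isopropyl, cyclopentyl or an unsubstituted ring nitrogen would fall on the same side of ethyl remains open. One step sets no trend with substituent size on this nitrogen.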